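Chloro for Methyl, Repeated on a Second Core

This account rests on a few compounds, and the source may have more. Where it says the series, first, only, none or still open, it means among the compounds named here.

Compound 1 `Cc1ccc(NC(=O)COc2nc3ccccc3nc2C)cc1` and compound 2 `Cc1nc2ccccc2nc1OCC(=O)Nc1ccc(Cl)cc1` share one core, while compound 3 `Cc1ccc(C(=O)Nc2ccc(Cn3c(=O)c(C)nc4ccccc43)cc2)cc1` and compound 4 `Cc1nc2ccccc2n(Cc2ccc(NC(=O)c3ccc(Cl)cc3)cc2)c1=O` share another; the difference between the two cores is not broken down here. All four belong to a functional assay on PC-3 cells (Homo sapiens) for inhibition, read by MTT assay, with a stated time of 24 h; a lower number here means a stronger inhibitor, a higher number a weaker inhibitor. Compound 1 reaches only the limit of the test, giving > 100000 nM. Compound 2 gives 68100 nM. The change between these two is chloro in place of methyl on an aromatic carbon, and it made an at least 1.4-fold lower number from compound 1 to compound 2 (0.16 log units; that floor lies within the scatter). Compound 3 also reaches only the limit, giving > 100000 nM. The same change is now made on its core, namely (chloro in place of methyl on an aromatic carbon), in the same place as before. Both pairs start from a compound sitting at the limit of > 100000 nM in this assay, at which 2 of the 3 values shown sit, so little room for a clear reading exists. From compound 3 to compound 4 the step is expected to be an at least 1.1-fold lower number from compound 3 to compound 4 (0.04 log units; that floor lies within the scatter). This expectation rests on the earlier pair, where an at least 1.4-fold lower number from compound 1 to compound 2 (0.16 log units; that floor lies within the scatter) stayed within the usual scatter, which leaves the outcome close to where compound 3 stands. Compound 4 is therefore estimated at 90000 nM, with a likely range from 40000 nM to 250000 nM.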

Compound 4, half-maximal inhibitory concentration: 39600 nM
The estimate for compound 4 lay 2.3-fold (0.36 log units) above the measured number; the measured number lies below the stated range.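

Carried to the second core in this assay, chloro in place of methyl on an aromatic carbon gives an at least 2.5-fold lower number from compound 3 to compound 4 (0.40 log units; beyond the scatter), a step that clears the usual scatter. Set beside the first core, both steps run towards a lower number, but only the second is beyond the scatter, so the series supports the same direction on two cores without showing that the change has the same size on each: the same change on two cores in this assay, an at least 1.4-fold lower number (0.16 log units; that floor lies within the scatter) from compound 1 to compound 2 and an at least 2.5-fold lower number (0.40 log units; beyond the scatter) from compound 3 to compound 4; the limit leaves it open whether they differ Neither step has an exact size either, since compound 1 and compound 3 each stand at a limit of the assay and not at a measured number: the limit of > 100000 nM in this assay, at which 2 of the 4 values shown sit.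

The compounds shown leave open whether the lower number is special to chloro or would also appear with another group in the same place, such as fluoro, methoxy or an amine. Going by these compounds alone, they also leave open whether the change would work the same way on a third core, as only two cores appear here.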